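This account rests on a few compounds, and the source may have more. Where it says the series, first, only, none or still open, it means among the compounds named here.

Compound 1 `CCC1=C(O)c2c(oc(-c3ccccc3F)cc2=O)C(CC)(CC)C1=O`: 3.93 uM
Compound 2 `CCC1=C(O)c2c(oc(-c3ccc(C)c(C)c3)cc2=O)C(CC)(CC)C1=O`: 0.71 uM

In a functional assay on KBVIN cells (Homo sapiens) for antiproliferative activity, read by sulforhodamine B assay, with a stated time of 3 days (on this read-out higher numbers stand for an effect only at larger amounts of compound and lower numbers for an effect already at smaller amounts), compound 2 holds the lower of the two numbers, at 0.71 uM. Compound 3 `CCC1=C(O)c2c(oc(-c3cc(C)c(C)cc3C)cc2=O)C(CC)(CC)C1=O` differs from it by methyl in place of hydrogen on an aromatic carbon, ortho to a large group. For the measured compounds named here, the only measured step, a 5.5-fold lower number from compound 1 to compound 2 (0.74 log units; beyond the scatter), is modest and swaps one whole aryl group for another, so it bears only loosely on a single added methyl. Going by the values given here, no measured step isolates that methyl. The expected change is small, a slight rise if any: a 1.3-fold higher number from compound 2 to compound 3 (0.10 log units; within the scatter), not expected to lie beyond the scatter. Compound 3 is expected at 0.9 uM, with an estimated range of 0.3 uM to 2.5 uM.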

Compound 3, concentration for half-maximal effect: 4.37 uM
The estimate for compound 3 lay 4.9-fold (0.69 log units) below the measured number, outside the stated range (above it).
By their numbers in this assay, from the lowest: compound 2; then compounds 1 and 3 (each within the scatter of the next).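

In this assay, the aromatic carbon ortho to a large group does not tolerate every substituent: methyl in place of hydrogen there gives a 6.2-fold higher number from compound 2 to compound 3 (0.79 log units; beyond the scatter). The 2,4,5-trimethylphenyl group also gives a 1.1-fold higher number from compound 1 to compound 3 (0.05 log units; within the scatter), so this one methyl removes the advantage that the 3,4-dimethylphenyl group held over the 2-fluorophenyl group. Nothing available explains the loss.

Still open, from the compounds shown here alone, is whether the rise is specific to methyl, or whether a methoxy group or an amine at this place would give the same number.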